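The source may report more compounds than this note shows. Statements on the series, on what has been measured and on what is new or still open speak of the compounds shown alone.

Of the compounds shown here, three built on the same shared core have been tested, and they differ in the aromatic ring attached to the ring nitrogen. Compound 1 `C#CCSc1nc(Nc2ccc(OC)cc2)c(C#N)c(-c2ccccc2)n1` gives 35600 nM in a functional assay on MCF7 cells (Homo sapiens) for inhibition, read by MTT assay, with a stated time of 72 h; a higher number here means a weaker inhibitor, a lower number a stronger inhibitor. Compound 2 `COc1ccc(Nc2nc(SCc3cn(Cc4ccccc4Cl)nn3)nc(-c3ccccc3)c2C#N)cc1` gives 8050 nM in this assay. Compound 3 `N#Cc1c(Nc2ccc(Cl)cc2)nc(SCc2cn(Cc3ccccc3Cl)nn2)nc1-c1ccccc1` gives 6520 nM in this assay. Compound 3 has the lowest number of the three, but its nearest neighbour is compound 2, and the step of a 1.2-fold lower number from compound 2 to compound 3 (0.09 log units; within the scatter) is within the scatter, so these two cannot be ranked against each other; only the gap between compound 3 and compound 1 lies beyond the scatter.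

Compound 4 `Cc1cccc(Nc2nc(SCc3cn(Cc4ccccc4Cl)nn3)nc(-c3ccccc3)c2C#N)c1` differs from compound 3 by 3-methylphenyl in place of 4-chlorophenyl on a nitrogen on an aromatic ring. Among the measured compounds shown here, the only measured step that touches this same position is a 1.2-fold lower number from compound 2 to compound 3 (0.09 log units; within the scatter), and it was small. For the measured compounds named here, no measured compound carries a group with the same name as the one that enters, so the direction is uncertain, and the step of a 1.1-fold higher number from compound 3 to compound 4 (0.03 log units; within the scatter) is expected to stay within the scatter. Compound 4 is therefore estimated at 7000 nM in this assay, with a range from 3000 nM to 17000 nM.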

Compound 4, half-maximal inhibitory concentration: 19600 nM
The estimate for compound 4 lay 2.8-fold (0.45 log units) below the measured number; the measured number lies above the stated range.
By their numbers in this assay, from the lowest: compounds 3 and 2 (each within the scatter of the next); then compounds 4 and 1 (each within the scatter of the next).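

In this assay, this position on the nitrogen is not indifferent to what it carries: 3-methylphenyl gives a 3.0-fold higher number from compound 3 to compound 4 (0.48 log units; beyond the scatter) and a 2.4-fold higher number from compound 2 to compound 4 (0.39 log units; beyond the scatter), both modest but beyond the scatter, whereas 4-chlorophenyl and 4-methoxyphenyl could not be told apart. The aromatic ring itself stays in all three compounds, so the difference lies in what the ring carries and where, and swapping one para-free name for another is not needed to see that the position can respond. Nothing at hand explains the rise in number.

The compounds shown leave open whether the methyl group or its place on the ring accounts for the step. A 4-methylphenyl or 3-chlorophenyl group on the same nitrogen would separate these two readings.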